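Series notes: methoxy to trifluoromethoxy on the sulfur-linked ring

This account rests on a few compounds, and the source may have more. Where it says the series, first, only, none or still open, it means among the compounds named here.

Two compounds carry numbers in an assay on cells for inhibition of Polyunsaturated fatty acid 5-lipoxygenase (Homo sapiens), read by HPLC, with a stated time of 15 min; a higher number here means a weaker inhibitor, a lower number a stronger inhibitor. Compound 1 `CCOC(=O)c1c(CSc2ccccc2OC)n(C)c2ccc(O)cc12` gives 5100 nM in this assay. Compound 2 `CCOC(=O)c1c(CSc2ccc(OC)cc2)n(C)c2ccc(O)cc12` gives 3100 nM in this assay. Within the data shown here, the only measured step, a 1.6-fold lower number from compound 1 to compound 2 (0.22 log units; within the scatter), concerns 4-methoxyphenyl in place of 2-methoxyphenyl on a sulfur. On the numbers shown, compound 2 stands at the lower of the two, with compound 1 nearest, but the gap stays within the scatter, so no order between them is claimed.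

Compound 3 `CCOC(=O)c1c(CSc2ccc(OC(F)(F)F)cc2)n(C)c2ccc(O)cc12` has not yet been measured. It differs from compound 2 by trifluoromethyl in place of methyl on an oxygen on an aromatic ring. Among the measured compounds shown here, no measured step concerns a change of this kind: the single step from compound 1 to compound 2 exchanges one methoxyphenyl for another on the sulfur and leaves the methyl itself untouched. The data give no direction for the methyl to trifluoromethyl exchange, and nothing beyond the scatter is expected in this assay. The expected step of a 1.2-fold lower number from compound 2 to compound 3 (0.09 log units; within the scatter) is therefore small. Compound 3 is estimated at 2500 nM in this assay, with a range from 800 nM to 8000 nM.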

Compound 3, half-maximal inhibitory concentration: 2100 nM
Compound 3: the middle estimate sits 1.2-fold (0.08 log units) above what was measured; low and high end bracket the measured number.
By their numbers in this assay, from the lowest: compounds 3, 2 and 1 (each within the scatter of the next, the first and the last beyond it).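

In this assay, the step on the methyl of the oxygen itself gives a 1.5-fold lower number from compound 2 to compound 3 (0.17 log units; within the scatter), so trifluoromethyl in place of methyl at this place on the sulfur-linked ring leaves the number within the scatter. Compound 1 and compound 2 differ only in 2-methoxyphenyl against 4-methoxyphenyl on the sulfur, with the methoxy unchanged; compound 3 adds a reading on the group itself and shows that this larger group, with no change in the counted hydrogen-bond donors or acceptors, is tolerated in this assay without a step beyond the scatter. Among these compounds, nothing available offers an explanation for this result, and the series so far contains no step beyond the scatter for a single change.

Still open, on these data alone, is whether a clearly different group on this oxygen, such as a longer chain like propyl, or a group in place of the whole ether, such as an amine or a carboxylic acid, would move the number beyond the scatter. Also open, as far as these compounds go, is whether the same exchange of methyl for trifluoromethyl on compound 1 would give a step of similar size.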